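Methyl branching on the amine substituent of the quinazolinol series

The source may report more compounds than this note shows. Statements on the series, on what has been measured and on what is new or still open speak of the compounds shown alone.

Working notes. Compound 1 `Oc1nc(NCc2ccccc2)nc2ccc(Cl)cc12` gives 3200 nM in a functional assay (aorta) for inhibition, with Rattus norvegicus as the target; a higher number here means a weaker inhibitor, a lower number a stronger inhibitor. Compound 2 `C[C@@H](Nc1nc(O)c2cc(Cl)ccc2n1)c1ccccc1` gives 2800 nM in this assay. The change between them is methyl in place of hydrogen on a saturated chain carbon bound to an aromatic carbon and a nitrogen on an aromatic ring, and its step is a 1.1-fold lower number from compound 1 to compound 2 (0.06 log units; within the scatter). Compound 3 `CCC(C)Nc1nc(O)c2cc(I)ccc2n1` gives 8900 nM in this assay, the highest of the three numbers; the difference between its core and that of compound 1 is not broken down here.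

Compound 4 `CC(C)C(C)Nc1nc(O)c2cc(I)ccc2n1` is not yet measured. Relative to compound 3 the change is methyl in place of hydrogen on a saturated chain carbon bound to two saturated chain carbons. This is the same kind of change as that from compound 1 to compound 2, but the place differs: there the methyl enters on a saturated chain carbon bound to an aromatic carbon and a nitrogen on an aromatic ring, here on a saturated chain carbon bound to two saturated chain carbons. Within the data shown here, only one measured instance of methyl for hydrogen exists, so the expectation rests on that single step. The expected step is a 1.1-fold lower number from compound 3 to compound 4 (0.05 log units; within the scatter), which is estimated to stay within scatter, like a 1.1-fold lower number from compound 1 to compound 2 (0.06 log units; within the scatter). Compound 4 is therefore expected to give about 8000 nM in this assay, estimated between 3500 nM and 18000 nM.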

Compound 4, half-maximal inhibitory concentration: 4100 nM
The estimate for compound 4 lay 2.0-fold (0.29 log units) above the measured number; low and high end bracket the measured number.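

In this assay, methyl in place of hydrogen on a saturated chain carbon bound to two saturated chain carbons gives a 2.2-fold lower number from compound 3 to compound 4 (0.34 log units; beyond the scatter). Set beside the earlier instance of methyl for hydrogen, this step gives no sign that the change behaves differently on the two cores, even though only this step lies beyond the scatter: the same change on two cores in this assay, a 1.1-fold lower number (0.06 log units; within the scatter) from compound 1 to compound 2 and a 2.2-fold lower number (0.34 log units; beyond the scatter) from compound 3 to compound 4, 1.9-fold (0.28 log units) apart, within the scatter of two such steps

Among these compounds, this does not establish a constant effect across the series: there are only two pairs, and they differ in the place of the methyl as well as in the core, so the influence of core and place cannot be separated.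

Still open, going by these compounds, is whether the same methyl, entering at one identical place on both cores, would give a matching step. Also open, on these data alone, is how a longer chain, an amine or a carboxylic acid on the amine substituent would compare with the sec-butyl and 1,2-dimethylpropyl groups of compound 3 and compound 4.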